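Swapping trifluoromethyl for fluoro on the aryl ring

The source may report more compounds than this note shows. Statements on the series, on what has been measured and on what is new or still open speak of the compounds shown alone.

Measured so far:
compound 1, `c1ccc(-n2nncc2-c2cccnc2)cc1`, 39.7 mg/kg
compound 2, `FC(F)(F)c1ccc(-n2nncc2-c2cccnc2)cc1`, 90.5 mg/kg

Both compounds were tested in a functional assay on the whole organism with Mus musculus as the target; a higher number here means that more compound is needed for the effect, a lower number that less compound is needed. Going by the values given here, compound 1 gives 39.7 mg/kg and compound 2 gives 90.5 mg/kg; the single step seen so far, a 2.3-fold higher number from compound 1 to compound 2 (0.36 log units; beyond the scatter), puts compound 2 at the higher of the two numbers.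

Compound 3, `Fc1ccc(-n2nncc2-c2cccnc2)cc1`, has not been measured. It differs from compound 2 in one way: fluoro in place of trifluoromethyl on an aromatic carbon. This is a partial return toward compound 1, which carries hydrogen at the same place. Among the compounds with values here, the only step that bears on it is a 2.3-fold higher number from compound 1 to compound 2 (0.36 log units; beyond the scatter); with fluoro lying between hydrogen and trifluoromethyl in what it brings, a smaller step in the opposite direction is expected, giving a 1.6-fold lower number from compound 2 to compound 3 (0.22 log units; within the scatter). Compound 3 is therefore estimated at 55 mg/kg in this assay, with a likely range from 28 mg/kg to 110 mg/kg.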

Compound 3, dose for half-maximal effect: 47.9 mg/kg
Compound 3: middle estimate off by 1.1-fold (0.06 log units), on the high side; low and high end bracket the measured number.
By their numbers in this assay, from the lowest: compounds 1, 3 and 2 (each within the scatter of the next, the first and the last beyond it).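

In this assay, fluoro on this aromatic carbon cannot be told apart from hydrogen, with a 1.2-fold higher number from compound 1 to compound 3 (0.08 log units; within the scatter), and it cannot be told apart from trifluoromethyl either, with a 1.9-fold lower number from compound 2 to compound 3 (0.28 log units; within the scatter). Among these three compounds, only hydrogen and trifluoromethyl differ beyond the scatter, so this place accepts a single fluorine without a clear change, and a difference appears only with the whole trifluoromethyl group. Nothing available here explains why this place responds in this way.

These compounds leave open how a methoxy group, an amine or a carboxylic acid would behave at this same place. They also do not show whether fluoro or trifluoromethyl on another carbon of the ring would give the same picture.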